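Swapping 3,5-dimethoxyphenyl for 2,3,6-trifluorophenyl in a small series

The source may hold more compounds than are shown below. What is called first, only, known or untested is meant among the compounds shown, and "the series" means these compounds.

- compound 1 `Cc1cccc(CNc2ncnc3c2ncn3[C@@H]2O[C@H](CO)[C@@H](O)[C@H]2O)c1` gives 19100 nM
- compound 2 `OC[C@H]1O[C@@H](n2cnc3c(NCc4ccc(Cl)cc4Cl)ncnc32)[C@H](O)[C@@H]1O` gives 86700 nM
- compound 3 `COc1cc(CNc2ncnc3c2ncn3[C@@H]2O[C@H](CO)[C@@H](O)[C@H]2O)cc(OC)c1` gives > 166000 nM (a limit)

All three values come from a functional assay on CCRF-CEM cells (Homo sapiens) for antiproliferative activity, with a stated time of 72 h (on this read-out higher numbers stand for weaker inhibition and lower numbers for stronger inhibition), and share one core. For compound 3, the entry of > 166000 nM is a limit of the assay and not a number. The next compound to be measured is compound 4 `OC[C@H]1O[C@@H](n2cnc3c(NCc4c(F)ccc(F)c4F)ncnc32)[C@H](O)[C@@H]1O` and its difference from compound 3 is this: 2,3,6-trifluorophenyl in place of 3,5-dimethoxyphenyl on a saturated chain carbon bound to a nitrogen on an aromatic ring and it lies on a saturated chain carbon bound to a nitrogen on an aromatic ring.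

Three measured steps change this same group. Replacing 3-methylphenyl with 2,4-dichlorophenyl gave a 4.5-fold higher number from compound 1 to compound 2 (0.66 log units; beyond the scatter) and replacing it with 3,5-dimethoxyphenyl gave an at least 8.6-fold higher number from compound 1 to compound 3 (0.93 log units; beyond the scatter). The remaining swap gave an at least 1.9-fold higher number from compound 2 to compound 3 (0.28 log units; that floor lies within the scatter) so those two compounds are not clearly separated. Going by the values given here, compound 2 is the only measured compound with halogens on this ring, which makes its value of 86700 nM the closest guide to compound 4, although fluorine has not been tested here. A lower number than the limit of compound 3 is therefore expected, but the size of the step remains uncertain. The estimated change is an at least 2.7-fold lower number from compound 3 to compound 4 (0.44 log units; beyond the scatter) and it may prove small. The expected value for compound 4 is 60000 nM with an estimated range from 20000 nM to 160000 nM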

Compound 4, half-maximal inhibitory concentration: 90300 nM
Compound 4: the middle estimate sits 1.5-fold (0.18 log units) below what was measured, within the range that was stated.
By their numbers in this assay, from the lowest: compound 1; then compounds 2 and 4 (each within the scatter of the next). At a limit, above all of these: compound 3.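

In this assay, going by these compounds alone, fluorine on this ring is tested for the first time, and the 2,3,6-trifluorophenyl group of compound 4 cannot be told apart from the 2,4-dichlorophenyl group of compound 2, with a 1.0-fold higher number from compound 2 to compound 4 (0.02 log units; within the scatter) on a saturated chain carbon bound to a nitrogen on an aromatic ring. Both halogen-bearing rings therefore sit apart from the 3-methylphenyl group of compound 1, with a 4.7-fold higher number from compound 1 to compound 4 (0.67 log units; beyond the scatter) matching in size the earlier step to compound 2. Compound 3 carries a limit and not a number, so an at least 1.8-fold lower number from compound 3 to compound 4 (0.26 log units; that floor lies within the scatter) gives only a floor and does not show that the 2,3,6-trifluorophenyl group truly improves on the 3,5-dimethoxyphenyl group: the limit of > 166000 nM in this assay, at which 1 of the 4 values shown sits.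

The compounds shown leave open whether an amine or a carboxylic acid on this ring, or a longer chain in place of the saturated chain carbon, could bring the number lower than that of compound 1. With a single fluorine-bearing ring among them, they also leave open whether the number or the placement of the fluorines matters at all.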